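The source may hold more compounds than are shown below. What is called first, only, known or untested is meant among the compounds shown, and "the series" means these compounds.

Working notes on the series, read in a functional assay on BXPC-3 cells (Homo sapiens) for inhibition, read by XTT assay, with a stated time of 72 h; on this read-out higher numbers stand for weaker inhibition and lower numbers for stronger inhibition. Compound 1 (`CC(C)(C)OC(=O)N1CCC[C@H]1COCCCCCC/C=C/c1ccc(-c2ccccc2)cc1`) gives > 100000 nM, which is a limit and not a number. Among the measured compounds shown here, compound 2 (`O=CN1CCC[C@H]1COCCCCCC/C=C/c1ccc(-c2ccccc2)cc1`) gives 53300 nM, the only actual number so far, so it has no measured value to be ranked against.

Compound 3 (`CC(C)(C)OC(=O)NCC(=O)N1CCC[C@H]1COCCCCCC/C=C/c1ccc(-c2ccccc2)cc1`) keeps the shared core and alters only the group on the carbonyl carbon: ((tert-butoxycarbonyl)amino)methyl in place of hydrogen on a carbonyl carbon. In words, this is ((tert-butoxycarbonyl)amino)methyl in place of hydrogen, or formyl to (((tert-butoxycarbonyl)amino)methyl)carbonyl.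

For the measured compounds named here, one measured step bears on this change, as it also alters the group on that carbonyl carbon: an at least 1.8-fold lower number from compound 1 to compound 2 (0.27 log units; that floor lies within the scatter). Its size is open on one side, and the evidence is bounded by the limit of > 100000 nM in this assay, at which 1 of the 2 values shown sits. It is weak guidance, and it concerns a different group from the one entering here. No step beyond the scatter is therefore expected in this assay, with any drift expected towards a higher number and a real chance of another limit. The expected step is a 1.1-fold higher number from compound 2 to compound 3 (0.05 log units; within the scatter). For compound 3 the estimated value is 60000 nM, with an expected range of 25000 nM to 100000 nM.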

Compound 3, half-maximal inhibitory concentration: 66700 nM
Compound 3: middle estimate off by 1.1-fold (0.05 log units), on the low side, within the range that was stated.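

In this assay, putting ((tert-butoxycarbonyl)amino)methyl in place of hydrogen on this carbonyl carbon, whose other neighbour is an amide-type nitrogen in a ring, gives no step beyond the scatter: a 1.3-fold higher number from compound 2 to compound 3 (0.10 log units; within the scatter). The entering group brings 9 heavy atoms, 1 hydrogen-bond donor and 2 hydrogen-bond acceptors, and compound 3 still gives a measured number, so this position accepts that much added structure without a readable change from the formyl compound. Compared with tert-butoxy on the same carbonyl carbon, the reading is an at least 1.4-fold lower number from compound 1 to compound 3 (0.17 log units; that floor lies within the scatter), which is only a floor, as compound 1 stands at a limit and not at a number: the limit of > 100000 nM in this assay, at which 1 of the 3 values shown sits.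

No step shown at this position lies beyond the scatter, so it remains open whether any group on this carbonyl carbon can move the value by a real amount. A free amine in place of the tert-butoxycarbonyl-protected amino group, a carboxylic acid or a longer chain on that carbon would test this, and the compounds shown say nothing about any of them.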